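Chloro addition on the trifluoromethylphenyl urea of compound 1

The source may report more compounds than this note shows. Statements on the series, on what has been measured and on what is new or still open speak of the compounds shown alone.

Measured in a functional assay on LOX IMVI cells (Homo sapiens) for inhibition, read by sulforhodamine B assay, with a stated time of 48 h; a lower number here means that less compound is tolerated, a higher number that more compound is tolerated:
compound 1 `O=C(Nc1cccc(-n2cc(-c3ccncc3)c(-c3ccc(Cl)c(O)c3)n2)c1)Nc1cccc(C(F)(F)F)c1`: 32400 nM
compound 2 `COc1cc(-c2nn(-c3cccc(NC(=O)Nc4cccc(C(F)(F)F)c4)c3)cc2-c2ccncc2)ccc1Cl`: 3460 nM
compound 3 `O=C(Nc1cccc(-n2cc(-c3ccncc3)c(-c3ccc(Cl)c(O)c3)n2)c1)Nc1cc(C(F)(F)F)cc(C(F)(F)F)c1`: 2750 nM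

Compound 1 gives the highest number of the three; compound 2 and compound 3 both sit well below it, beyond the scatter.

Compound 4 `O=C(Nc1cccc(-n2cc(-c3ccncc3)c(-c3ccc(Cl)c(O)c3)n2)c1)Nc1ccc(Cl)c(C(F)(F)F)c1` differs from compound 1 by chloro in place of hydrogen on an aromatic carbon, taking the 3-(trifluoromethyl)phenyl to 4-chloro-3-(trifluoromethyl)phenyl.

Two steps from compound 1 are known. Methylation on an oxygen gave a 9.4-fold lower number from compound 1 to compound 2 (0.97 log units; beyond the scatter); a second trifluoromethyl on an aromatic carbon gave a 12-fold lower number from compound 1 to compound 3 (1.07 log units; beyond the scatter). The step to compound 4 is also a substitution on an aromatic carbon, so a lower number is expected, likely smaller than either known step since chloro is a single atom.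

Compound 4 is therefore estimated at 6000 nM, range 2000 nM to 18000 nM, meaning an expected 5.4-fold lower number from compound 1 to compound 4 (0.73 log units; beyond the scatter).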

Compound 4, concentration lethal to 50% of the cells: 2390 nM
Compound 4: middle estimate off by 2.5-fold (0.40 log units), on the high side; the measured number falls inside the stated range.
By their numbers in this assay, from the lowest: compounds 4, 3 and 2 (each within the scatter of the next); then compound 1.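

In this assay, a single chloro on the aromatic carbon ortho to the trifluoromethyl group is enough for a large step, a 14-fold lower number from compound 1 to compound 4 (1.13 log units; beyond the scatter), so the 3-(trifluoromethyl)phenyl ring of compound 1 responds to a one-atom addition. With compound 3, this makes two additions to that ring that both lower the number, and no compound shown goes against this. No measurement shown accounts for the step.

From the compounds shown here alone, whether fluoro, methyl or an amine on the same carbon would give a similar step stays open. Also open, going by these compounds, is how this chloro would combine with the methyl on oxygen of compound 2.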